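A few compounds are considered here, and "the series" means these few. Any claim that something is new, unique, unknown or untested is made for them only; others in the source may bear on it.

In a functional assay on MCF7 cells (Homo sapiens) for cytotoxicity, read by MTT assay, with a stated time of 48 h (on this read-out higher numbers stand for weaker inhibition and lower numbers for stronger inhibition), compound 1 `COc1cc(-n2c(-c3ccc(Br)cc3)cn(C(C)=O)c2=O)cc(OC)c1OC` gives 10600 nM. Compound 2 `COc1cc(-n2c(-c3ccc([N+](=O)[O-])cc3)cn(C(C)=O)c2=O)cc(OC)c1OC` gives > 50000 nM, which is a limit and not a number. Going by these compounds, compound 3 `COc1ccc(-c2cn(C(C)=O)c(=O)n2-c2cc(OC)c(OC)c(OC)c2)cc1[N+](=O)[O-]`, which also carries a nitro group, gives > 50000 nM, again a limit, so its true position is unknown. Compound 4 `COc1ccc(-c2cn(C(C)=O)c(=O)n2-c2cc(OC)c(OC)c(OC)c2)cc1N` has amino in place of nitro on an aromatic carbon. Within the data shown here, the one measured step involving nitro is an at least 4.7-fold higher number from compound 1 to compound 2 (0.67 log units; beyond the scatter), with nitro in place of bromo. Among the measured compounds shown here, no amino compound has been measured, so this is only a loose guide, but losing the nitro group may lower the number. The expected change is an at least 2.5-fold lower number from compound 3 to compound 4 (0.39 log units; beyond the scatter), towards stronger inhibition. For compound 4, the estimated value is 20000 nM, with a range of 5000 nM to 50000 nM.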

Compound 4, half-maximal inhibitory concentration: 43400 nM
Estimate against measurement, compound 4: 2.2-fold (0.34 log units) below, and the stated range covers the measured number.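

In this assay compound 4 gives a true number where compound 3 gave only a limit, so this position, ortho to a methoxy group, now has a measured value with amino on it. Against the bromo compound the result is a 4.1-fold higher number from compound 1 to compound 4 (0.61 log units; beyond the scatter), towards weaker inhibition. The steps of an at least 1.1-fold lower number from compound 3 to compound 4 (0.06 log units; that floor lies within the scatter) and an at least 1.1-fold lower number from compound 2 to compound 4 (0.06 log units; that floor lies within the scatter) cannot be read for size, since each starts from a limit: the limit of > 50000 nM in this assay, at which 2 of the 4 values shown sit.

Going by these compounds, whether a hydroxyl group or an acetamide in place of the amino group would give a lower number stays open.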